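The source may report more compounds than this note shows. Statements on the series, on what has been measured and on what is new or still open speak of the compounds shown alone.

Working notes on the urea series built on the shared core of compound 1 `COc1cc(-c2nn(-c3cccc(NC(=O)Nc4ccc(Cl)c(Cl)c4)c3)cc2-c2ccncc2)ccc1Cl`. In a functional assay on LOX IMVI cells (Homo sapiens) for inhibition, read by sulforhodamine B assay, with a stated time of 48 h (on this read-out higher numbers stand for lower toxicity in this test and lower numbers for higher toxicity in this test), compound 1 gives > 50000 nM, which is a limit of the assay and not a number, so that compound 1 stands at the limit of > 50000 nM in this assay, at which 1 of the 3 values shown sits. Compound 2 `O=C(Nc1cccc(-n2cc(-c3ccncc3)c(-c3ccc(Cl)c(O)c3)n2)c1)Nc1ccc(Cl)c(Cl)c1` carries a hydroxyl in place of the methoxy, and in this assay compound 2 gives 15000 nM; the step is an at least 3.3-fold lower number from compound 1 to compound 2 (0.52 log units; beyond the scatter). Within the data shown here, compound 3 `O=C(Nc1cccc(-n2cc(-c3ccncc3)c(-c3ccc(Cl)c(O)c3)n2)c1)Nc1cc(C(F)(F)F)cc(C(F)(F)F)c1` differs from compound 2 in the urea aryl group, and in this assay compound 3 gives 2750 nM; no step between these two is counted here, the two values simply stand side by side and show the lower number with the bis(trifluoromethyl) urea.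

Compound 4 `COc1cc(-c2nn(-c3cccc(NC(=O)Nc4ccc(Cl)c(C(F)(F)F)c4)c3)cc2-c2ccncc2)ccc1Cl` is compound 1 with trifluoromethyl in place of chloro on an aromatic carbon. Among the measured compounds shown here, no measured step covers this exchange; the only measured step, an at least 3.3-fold lower number from compound 1 to compound 2 (0.52 log units; beyond the scatter), concerns a different site. The expectation is therefore a modest downward step from the limit, an at least 1.2-fold lower number from compound 1 to compound 4 (0.09 log units; that floor lies within the scatter), with a real chance that compound 4 again returns only a limit. Compound 4 is estimated at 40000 nM, with a range from 12000 nM to 120000 nM.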

Compound 4, concentration lethal to 50% of the cells: 17900 nM
The estimate for compound 4 lay 2.2-fold (0.35 log units) above the measured number; the range from low to high includes it.
By their numbers in this assay, from the lowest: compound 3; then compounds 2 and 4 (each within the scatter of the next). At a limit, above all of these: compound 1.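

In this assay the urea aryl group now has a step of its own: trifluoromethyl in place of chloro gives an at least 2.7-fold lower number from compound 1 to compound 4 (0.44 log units; beyond the scatter) while the earlier step concerned only the substituent on oxygen. Among these compounds, this exchange brings a methoxy compound off the limit with the methoxy left in place, so the hydroxyl is not the only single change in these compounds that yields a measurable number. The size of this step is a floor and not a measured gap, because compound 1 stands at a limit of the assay: the limit of > 50000 nM in this assay, at which 1 of the 4 values shown sits.

On these data alone, whether the exchange would act the same way in a compound carrying the hydroxyl stays open. So does the outcome with a nitrile or a methyl group at this place on the urea aryl ring.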